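A few compounds are considered here, and "the series" means these few. Any claim that something is new, unique, unknown or untested is made for them only; others in the source may bear on it.

Measured compounds:
Compound 1, `Cc1ccc(C(=O)NCC(=O)N/N=C/c2ccccc2OCc2ccccc2Cl)cc1`, in a functional assay on HepG2 cells (Homo sapiens) for inhibition, read by MTT assay, with a stated time of 24 h (a higher number here means a weaker inhibitor, a lower number a stronger inhibitor), gives 13400 nM.
Compound 2, `Cc1ccc(C(=O)NCC(=O)N/N=C/c2cccc(OCc3ccccc3Cl)c2)cc1`, in this assay gives 47500 nM.
Compound 3, `O=C(CNC(=O)c1cccnc1Cl)N/N=C/c1ccccc1OCc1ccccc1Cl`, in this assay gives 16900 nM.

Compounds 1 and 2 carry the same atoms joined differently, and how their two cores differ is not broken down here. Compound 2 stands with the highest number of the three measured, beyond the scatter from both compound 1 and compound 3. Compound 3 differs from compound 1 by one change, (2-chloropyridin-3-yl in place of 4-methylphenyl on a carbonyl carbon), and this change made a step of a 1.3-fold higher number from compound 1 to compound 3 (0.10 log units; within the scatter).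

Compound 4, `O=C(CNC(=O)c1cccnc1Cl)N/N=C/c1cccc(OCc2ccccc2Cl)c1`, is not yet measured. It differs from compound 2 by the same kind of change, (2-chloropyridin-3-yl in place of 4-methylphenyl on a carbonyl carbon), at a place described in the same words as for compound 1 and compound 3. The expectation for compound 4 rests on compound 2 giving 47500 nM combined with the earlier step of a 1.3-fold higher number from compound 1 to compound 3 (0.10 log units; within the scatter); the step from compound 2 to compound 4 is expected to be about a 1.3-fold higher number from compound 2 to compound 4 (0.10 log units; within the scatter). In this assay compound 4 is therefore estimated to give 60000 nM, with a range from 30000 nM to 120000 nM.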

Compound 4, half-maximal inhibitory concentration: 3100 nM
For compound 4 the middle estimate is 19-fold (1.29 log units) above the measured one, and the stated range ends above it.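

In this assay, putting 2-chloropyridin-3-yl in place of 4-methylphenyl on a carbonyl carbon made a step of a 15-fold lower number from compound 2 to compound 4 (1.19 log units; beyond the scatter), and the two cores did not respond alike to this change: the same change on two cores in this assay, a 1.3-fold higher number (0.10 log units; within the scatter) from compound 1 to compound 3 and a 15-fold lower number (1.19 log units; beyond the scatter) from compound 2 to compound 4, 19-fold (1.29 log units) apart, beyond the scatter of two such steps The step measured on one core therefore could not be carried over to the other in this series, and the large drop seen with compound 4 is no general effect of the change, since the pair of compound 1 and compound 3 goes against it. These two pairs do not show why the cores respond differently, nor do they give a rule for any further core.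

The compounds shown leave open whether the chlorine or the ring nitrogen of the 2-chloropyridin-3-yl group accounts for the step on the core of compound 2. They also leave open how a 2-chlorophenyl or an unsubstituted pyridin-3-yl group on the same carbonyl carbon would behave on each of the two cores.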